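The compounds below may be only part of what the source reports. "The series", "measured", "known", "first", "only" and "open" are said of these compounds alone.

In a functional assay on MOLT-4 cells (Homo sapiens) for cytotoxicity, read by CCK-8 assay, with a stated time of 24 h (on this read-out higher numbers stand for weaker inhibition and lower numbers for stronger inhibition), compound 1 `C=CC(=O)N1C(=O)CC(c2ccc(Br)cc2)Sc2ccccc21` gives 106000 nM while compound 2 `C=CC(=O)N1C(=O)CC(c2ccc([N+](=O)[O-])cc2)Sc2ccccc21` gives 91500 nM and the two sit level within the scatter. Compound 3 `C=CC(=O)N1C(=O)CC(c2ccc(C#N)cc2)Sc2ccccc21` differs from compound 2 by cyano in place of nitro on an aromatic carbon, para to a large group (cyano in place of nitro on an aromatic carbon). Among the measured compounds shown here, the one measured step at this place, a 1.2-fold lower number from compound 1 to compound 2 (0.06 log units; within the scatter) for nitro in place of bromo, stayed within the scatter, so no step beyond the scatter is expected in this assay here. The expected outcome is a 1.0-fold higher number from compound 2 to compound 3 (0.02 log units; within the scatter) and thus no real change. Compound 3 is estimated at 95000 nM with a range from 55000 nM to 160000 nM expected.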

Compound 3, half-maximal inhibitory concentration: 88700 nM
Compound 3: middle estimate off by 1.1-fold (0.03 log units), on the high side; measured number inside the range.
By their numbers in this assay, from the lowest: compounds 3, 2 and 1 (each within the scatter of the next).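

In this assay, cyano at this place on the aromatic ring gives a 1.0-fold lower number from compound 2 to compound 3 (0.01 log units; within the scatter), and against bromo it gives a 1.2-fold lower number from compound 1 to compound 3 (0.08 log units; within the scatter). Bromo, nitro and cyano therefore all sit level here, and even the smaller cyano, with a triple bond instead of nitro's double bond, brings no real change. Nothing available explains this flat result. On these data alone, whether an amine or a carboxylic acid at this place would move the number remains open. So does whether a change elsewhere on the shared core would matter more.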